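The compounds below may be only part of what the source reports. "The series", "measured", "known", "first", "only" and "open" are said of these compounds alone.

Series notes. Compound 1 `CCCNC1=NS(=O)(=O)c2cc(Cl)ccc2N1` in a functional assay (aorta) with Rattus norvegicus as the target (a higher number here means that more compound is needed for the effect, a lower number that less compound is needed), gives 55.5 uM. Compound 2 `CCC(C)NC1=NS(=O)(=O)c2cc(Cl)ccc2N1` in this assay gives 15.5 uM. The change between them is methyl in place of hydrogen on a saturated chain carbon bound to an amine nitrogen and a saturated chain carbon, which made a 3.6-fold lower number from compound 1 to compound 2 (0.55 log units; beyond the scatter). Compound 3 `CC(C)NC1=NS(=O)(=O)c2cc(Br)ccc2N1` in this assay gives 4.8 uM, the lowest of the three numbers; the difference between the core of compound 1 and the core of compound 3 is not broken down here. Compound 4 `CCC(C)NC1=NS(=O)(=O)c2cc(Br)ccc2N1` is not yet measured. Its change from compound 3 is methyl in place of hydrogen on a saturated chain carbon, two bonds along the chain from an amine nitrogen. Among the compounds with values here, this is the same kind of change as the one from compound 1 to compound 2, but the place differs: there the carbon is bound to an amine nitrogen and a saturated chain carbon, here it is two bonds along the chain from an amine nitrogen. The step from compound 3 to compound 4 is expected at roughly a 2.2-fold lower number from compound 3 to compound 4 (0.34 log units; beyond the scatter), a little smaller than the earlier one. The place differs and the core differs, so the earlier step is only a rough guide. Compound 4 is estimated at 2.2 uM, with 0.7 uM to 7 uM as the likely span.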

Compound 4, concentration for half-maximal effect: 5.6 uM
Beside the measured number, compound 4's estimate is 2.5-fold (0.41 log units) below it; measured number inside the range.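

In this assay, the methyl step does not carry over unchanged from the chloro core to the bromo core: the same change on two cores in this assay, a 3.6-fold lower number (0.55 log units; beyond the scatter) from compound 1 to compound 2 and a 1.2-fold higher number (0.07 log units; within the scatter) from compound 3 to compound 4, 4.2-fold (0.62 log units) apart, beyond the scatter of two such steps On the bromo core, the methyl gives a 1.2-fold higher number from compound 3 to compound 4 (0.07 log units; within the scatter), while with the sec-butyl chain held, bromo in place of chloro gives a 2.8-fold lower number from compound 2 to compound 4 (0.44 log units; beyond the scatter). Within the data shown here, the two methyl steps also differ in place, and with only one pair per core the gap cannot be assigned to the core or to the place.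

The compounds shown leave open how an isopropyl chain behaves on the chloro core and a propyl chain on the bromo core, the pairings that would separate these two factors. Also open, on these data alone, are a longer chain on the amine nitrogen and fluoro in place of the halogen.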